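A few compounds are considered here, and "the series" means these few. Any claim that something is new, unique, unknown or untested is made for them only; others in the source may bear on it.

Measured so far:
Compound 1 `CC(O)(C(=O)Nc1ccc(S(=O)(=O)c2ccccc2)c(F)c1)C(F)(F)F` — 1800 nM
Compound 2 `CC(O)(C(=O)Nc1ccc(S(=O)(=O)c2ccccc2F)cc1)C(F)(F)F` — 1300 nM
Compound 3 `CC(O)(C(=O)Nc1ccc(S(=O)(=O)c2cccc(F)c2)cc1)C(F)(F)F` — 3400 nM

All three share one core and were tested in a functional assay (Cavia porcellus) with sulfonylurea receptors; K-ATP channels (Homo sapiens) as the target; a higher number here means a weaker inhibitor, a lower number a stronger inhibitor. Compound 3 sits at the high end of the three numbers: the step of a 2.6-fold higher number from compound 2 to compound 3 (0.42 log units; beyond the scatter) is beyond the scatter, whereas compound 1 and compound 3 cannot be told apart, their two values falling within the scatter of each other.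

Compound 4 `CC(O)(C(=O)Nc1ccc(S(=O)(=O)c2ccc(F)cc2)cc1)C(F)(F)F` has not yet been measured. It differs from compound 3 in one place: 4-fluorophenyl in place of 3-fluorophenyl on a sulfonyl sulfur. Going by the values given here, only one measured step bears on this kind of change, namely moving the fluorine around the ring that sits on the sulfonyl sulfur, and that step, a 2.6-fold higher number from compound 2 to compound 3 (0.42 log units; beyond the scatter), was modest. Among the compounds with values here, there is no measured step that compares the 3-fluorophenyl with the 4-fluorophenyl directly, so the direction is open; a move of the fluorine within that ring has so far produced a change of modest size, and a step of similar size in either direction, or none beyond the scatter, is expected for this assay.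

On that basis compound 4 is expected to give about 2500 nM, with a plausible range from 1000 nM to 6000 nM, which corresponds to an expected step of a 1.4-fold lower number from compound 3 to compound 4 (0.13 log units; within the scatter).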

Compound 4, half-maximal inhibitory concentration: 8600 nM
Estimate against measurement, compound 4: 3.4-fold (0.54 log units) below; the measured number lies above the stated range.
By their numbers in this assay, from the lowest: compounds 2, 1 and 3 (each within the scatter of the next, the first and the last beyond it); then compound 4.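

In this assay, the place of the fluorine on the ring attached to the sulfonyl sulfur now forms an ordered series rather than a single comparison: after a 2.6-fold higher number from compound 2 to compound 3 (0.42 log units; beyond the scatter), the change to 4-fluorophenyl continues in the same direction, with a 2.5-fold higher number from compound 3 to compound 4 (0.40 log units; beyond the scatter) for two groups that have identical atoms. Taken end to end, the change from 2-fluorophenyl to 4-fluorophenyl gives a 6.6-fold higher number from compound 2 to compound 4 (0.82 log units; beyond the scatter) and is larger than either single move, so the position of one fluorine is enough to shift the number well beyond the scatter. Among these three fluorinated isomers, the number rises in that order and no compound goes against the pattern, although the data available here offer no explanation for it.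

The compounds shown leave open whether a chlorine atom or a methoxy group on this ring would follow the same order as fluorine. They also leave open how a plain phenyl group on the sulfonyl sulfur would compare when the shared core carries no fluorine on its other ring.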